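A few compounds are considered here, and "the series" means these few. Any claim that something is new, unique, unknown or untested is made for them only; others in the source may bear on it.

Among the measured compounds shown here, compound 3 `FC(F)(F)c1ccc(CSc2nc(N3CCCCC3)c3ccccc3n2)cc1` gives 25500 nM in a functional assay on PC-3 cells (Homo sapiens) for cytotoxicity, read by MTT assay, with a stated time of 72 h (on this read-out higher numbers stand for weaker inhibition and lower numbers for stronger inhibition), the highest of the three numbers measured so far. Compound 1 `CCCCCCNc1nc(SCc2ccc(C(F)(F)F)cc2)nc2ccccc12` gives 19000 nM in this assay, and compound 2 `CCCCCCCCNc1nc(SCc2ccc(C(F)(F)F)cc2)nc2ccccc12` gives 10500 nM in this assay. The step of a 1.3-fold higher number from compound 1 to compound 3 (0.13 log units; within the scatter) lies within the scatter, whereas the step of a 2.4-fold higher number from compound 2 to compound 3 (0.39 log units; beyond the scatter) is a modest one. Compound 4 `FC(F)(F)c1ccc(CSc2nc(Nc3ccccc3)c3ccccc3n2)cc1` differs from compound 3 by anilino in place of piperidin-1-yl on an aromatic carbon. For the measured compounds named here, no measured step covers an aromatic amine at this carbon; both steps set open-chain amines against the piperidin-1-yl ring, and neither gives the amine-bearing compound a higher number than compound 3. The step of a 1.8-fold lower number from compound 1 to compound 2 (0.26 log units; within the scatter) also lies within the scatter. On that basis compound 4 is expected to show a small lowering of the number, a 1.4-fold lower number from compound 3 to compound 4 (0.15 log units; within the scatter), or none beyond the scatter. Compound 4 is therefore estimated at 18000 nM in this assay, with a range from 7000 nM to 45000 nM.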

Compound 4, half-maximal inhibitory concentration: 20000 nM
Beside the measured number, compound 4's estimate is 1.1-fold (0.05 log units) below it, within the range that was stated.
By their numbers in this assay, from the lowest: compounds 2, 1, 4 and 3 (each within the scatter of the next, the first and the last beyond it).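

Among the compounds shown here, the anilino group puts an aromatic ring on this nitrogen, a kind of substituent the earlier compounds did not show, and in this assay its exchange for piperidin-1-yl gives a 1.3-fold lower number from compound 3 to compound 4 (0.11 log units; within the scatter), so this change at the carbon next to the ring nitrogen has no effect that can be told from the scatter. Phenyl in place of hexyl gives a 1.1-fold higher number from compound 1 to compound 4 (0.02 log units; within the scatter), and phenyl in place of octyl gives a 1.9-fold higher number from compound 2 to compound 4 (0.28 log units; within the scatter), so compound 4 cannot be separated from either open-chain amine, and this position tolerates all of these groups with little difference in the number. Nothing available here offers an explanation for this result.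

On these data alone, it remains open whether a methoxy or chloro group on the anilino ring, or morpholine in place of piperidin-1-yl, would move the number beyond the scatter of compound 4. As far as these compounds go, whether a chain longer than octyl would do so is also open.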